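Working notes: shortening the butoxy chain of compound 1

The source may hold more compounds than are shown below. What is called first, only, known or untested is meant among the compounds shown, and "the series" means these compounds.

Measured in a functional assay (Homo sapiens) for inhibition; on this read-out lower numbers stand for stronger inhibition and higher numbers for weaker inhibition:
compound 1 `CCCCOc1cccc(C(=O)/C=C/c2ccc(OC)cc2OC)c1`: 65000 nM
compound 2 `C=CCOc1ccc(C(=O)/C=C/c2cc(OC)cc(OC)c2)cc1`: 25000 nM

Of the two measured values, compound 1 at 65000 nM stands highest and so shows the weaker inhibition. Compound 2 at 25000 nM lies lower, by more than the usual scatter. These two compounds differ in more than one place, so their gap does not isolate the effect of any single change.

Compound 3 `COc1cccc(C(=O)/C=C/c2ccc(OC)cc2OC)c1` departs from compound 1 in one place only: hydrogen in place of propyl on a saturated chain carbon bound to an oxygen on an aromatic ring. In words, this is hydrogen in place of propyl on a saturated chain carbon bound to an oxygen on an aromatic ring, or butoxy to methoxy. Among the measured compounds shown here, the series holds no measured single-place step to calibrate this change. In this assay, no step beyond the scatter is therefore expected, with only a slight lean towards a lower number. The estimated step of a 1.4-fold lower number from compound 1 to compound 3 (0.16 log units; within the scatter) reflects that expectation. For compound 3 the expected value is 45000 nM, with an estimated range of 15000 nM to 120000 nM.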

Compound 3, half-maximal inhibitory concentration: 42000 nM
The estimate for compound 3 lay 1.1-fold (0.03 log units) above the measured number; low and high end bracket the measured number.
By their numbers in this assay, from the lowest: compounds 2, 3 and 1 (each within the scatter of the next, the first and the last beyond it).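

Among the compounds shown here, compound 3 gives the first single-place step, and it bears directly on this position: in this assay, going from butoxy to methoxy gives a 1.5-fold lower number from compound 1 to compound 3 (0.19 log units; within the scatter) and so stays inside the usual scatter. Removing the propyl from the saturated chain carbon bound to the oxygen therefore leaves no readable difference on the core of compound 1, and the length of this chain, between butoxy and methoxy, does not separate the two compounds on this read-out. No measured evidence bears on why this step is so small, and none is offered here.

Still open, going by these compounds, is whether a longer chain such as hexyloxy, or an amine or a carboxylic acid carried at the end of the chain, would move the number beyond the scatter, given that only butoxy and methoxy can be compared at this place. Also open, on these data alone, is whether the same change from butoxy to methoxy would read the same way on the core of compound 2.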